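Removing the cyclohexyl from a benzimidazole core: expected cytotoxicity

This account rests on a few compounds, and the source may have more. Where it says the series, first, only, none or still open, it means among the compounds named here.

Compound 1 `CCC(=O)Nc1ccc(-c2nc3cc(C(F)(F)F)ccc3n2C2CCCCC2)cc1`: 17000 nM
Compound 2 `Cn1c(-c2ccc(NC(=O)CN3CCCC3)cc2)nc2cc(C(F)(F)F)ccc21`: 16000 nM

In an ADME assay on MT4 cells (Homo sapiens) for cytotoxicity, read by MTT assay, with a stated time of 96 h (a higher number here means that more compound is tolerated, a lower number that less compound is tolerated), compound 1 gives 17000 nM and compound 2 gives 16000 nM; these two numbers lie within the scatter of each other, so neither stands apart. Compound 3 `CCC(=O)Nc1ccc(-c2nc3cc(C(F)(F)F)ccc3[nH]2)cc1` has not yet been measured. Its difference from compound 1 is hydrogen in place of cyclohexyl on an aromatic nitrogen. For the measured compounds named here, no step between measured compounds bears on this change, so only a modest shift is expected, if any, and the step from compound 1 to compound 3 is estimated as a 1.5-fold higher number from compound 1 to compound 3 (0.17 log units; within the scatter). Compound 3 is therefore expected to give about 25000 nM, within a range of 10000 nM to 60000 nM.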

Compound 3, half-maximal cytotoxic concentration: >= 100000 nM
Compound 3: a limit, no number; the forecaster's own chance of this, stated with the estimate: 25%; middle value at least 4.0-fold (0.60 log units) away from the limit.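

In this assay, the aromatic nitrogen proves to be a position where the change matters: hydrogen in place of cyclohexyl gives an at least 5.8-fold higher number from compound 1 to compound 3 (0.76 log units; beyond the scatter). No earlier pair of compounds differing in one place had shown any step at this position. Compound 3 gives >= 100000 nM, which is a limit of the assay and not a number: the limit of >= 100000 nM in this assay, at which 1 of the 3 values shown sits.

The compounds shown leave open how an ethyl or a phenyl on that aromatic nitrogen would read. They also do not tell whether the same step would appear with a different group on the amide.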